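A few compounds are considered here, and "the series" means these few. Any claim that something is new, unique, unknown or untested is made for them only; others in the source may bear on it.

Measured so far in a physicochemical assay for lipophilicity, using the shake flask method, measured as octanol-water partition, at pH 7.4; on this read-out higher numbers stand for higher lipophilicity and lower numbers for lower lipophilicity:
Compound 1 `C[C@@H](Nc1c(C(N)=O)cnc2ccc(-c3cccnc3)cc12)c1ccc(Cl)cc1`: > 4.3 (a limit)
Compound 2 `NC(=O)c1cnc2ccc(-c3cccnc3)cc2c1NCC1CCCCC1`: > 4.3 (a limit)

Compound 2 gives only a limit, > 4.3, and not a number. Within the data shown here, the same holds across the series so far: the limit of > 4.3 in this assay, at which 2 of the 2 values shown sit. Among the measured compounds shown here, the only measured step is a step that the two limits leave unreadable from compound 1 to compound 2. It offers no size to carry forward.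

Compound 3 `C[C@@H](Nc1c(C(N)=O)cnc2ccc(-c3cccnc3)cc12)C1CCOCC1` makes one change: 1-(oxan-4-yl)ethyl in place of cyclohexylmethyl on a nitrogen on an aromatic ring. In words, 1-(oxan-4-yl)ethyl comes in place of cyclohexylmethyl on a nitrogen on an aromatic ring, and a hydrogen-bond acceptor enters where there was none.

From this structural change alone, a fall in this assay is expected, with an uncertain starting point. The expected step is a number at least 0.70 log units lower from compound 2 to compound 3 (beyond the scatter). For compound 3 the estimate is 3.6, with an expected range of 2.9 to 4.3.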

Compound 3, distribution coefficient: 2.3
Estimate against measurement, compound 3: 1.30 log units above, outside the stated range (below it).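

In this assay, among these compounds, this place on a nitrogen on an aromatic ring now gives a readable change for the first time: 1-(oxan-4-yl)ethyl in place of cyclohexylmethyl gives a number at least 2.00 log units lower from compound 2 to compound 3 (beyond the scatter). Oxan-4-yl in place of 4-chlorophenyl gives a number at least 2.00 log units lower from compound 1 to compound 3 (beyond the scatter), so compound 3, the one compound here with a ring oxygen, stands clearly lower than both earlier compounds. The step between the two earlier compounds cannot be read, and their full distance to compound 3 stays unknown, because those values are limits and not numbers: the limit of > 4.3 in this assay, at which 2 of the 3 values shown sit.

Going by these compounds, the step to compound 3 brings both a ring oxygen and a changed chain, so the share of each stays open. Also open, on these data alone, is how a piperidin-4-yl group, with a ring nitrogen where compound 3 has its oxygen, would compare with oxan-4-yl.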